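This account rests on a few compounds, and the source may have more. Where it says the series, first, only, none or still open, it means among the compounds named here.

In an ADME assay on cells (Mus musculus, strain BALB/c) for cytotoxicity, read by MTT assay, with a stated time of 24 h (a higher number here means that more compound is tolerated, a lower number that less compound is tolerated), compound 1 `COc1cc(-c2nnc(SCc3ccc(Cl)cc3)o2)ccc1O` gives 480000 nM and compound 2 `COc1cc(-c2nnc(SCc3c(F)cccc3F)o2)ccc1O` gives 575000 nM. The step of a 1.2-fold higher number from compound 1 to compound 2 (0.08 log units; within the scatter) is within the scatter, so compound 2 holds one of two numbers that do not separate from each other. Compound 3 `COc1cc(-c2nnc(SCc3ccccc3)o2)ccc1O` differs from compound 2 by phenyl in place of 2,6-difluorophenyl on a saturated chain carbon bound to a sulfur. Going by the values given here, the only measured step at this position, a 1.2-fold higher number from compound 1 to compound 2 (0.08 log units; within the scatter), was within the scatter, so no step beyond the scatter is expected from compound 2 to compound 3 in this assay. Compound 3 is therefore estimated at 500000 nM, with a range of 300000 nM to 900000 nM. The expected step is a 1.2-fold lower number from compound 2 to compound 3 (0.06 log units; within the scatter).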

Compound 3, half-maximal cytotoxic concentration: 211000 nM
Beside the measured number, compound 3's estimate is 2.4-fold (0.37 log units) above it, outside the stated range (below it).
By their numbers in this assay, from the lowest: compound 3; then compounds 1 and 2 (each within the scatter of the next).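

In this assay this position does respond to change on a saturated chain carbon bound to a sulfur: phenyl in place of 2,6-difluorophenyl lowers the number (a 2.7-fold lower number from compound 2 to compound 3 (0.44 log units; beyond the scatter)) and hydrogen in place of chloro on an aromatic carbon lowers it as well (a 2.3-fold lower number from compound 1 to compound 3 (0.36 log units; beyond the scatter)). The 2,6-difluorophenyl and 4-chlorophenyl groups do not separate from each other, yet each separates from plain phenyl, with less compound tolerated without halogen in these three compounds. No measured evidence bears on the cause of this. Still open, as far as these compounds go, is whether an amine, a carboxylic acid or a longer chain at this place would shift the number further.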